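A fluorine swap on the benzyl group of compound 2

The source may hold more compounds than are shown below. What is called first, only, known or untested is meant among the compounds shown, and "the series" means these compounds.

Compound 1 `CS(=O)(=O)Nc1ccc2c(c1)S(=O)(=O)N=C(C1=C(O)[C@@H]3[C@H]4CC[C@H](C4)[C@@H]3N(Cc3ccccc3Cl)C1=O)N2` gives > 1 h, a limit.
Compound 2 `Cc1ccc(CN2C(=O)C(C3=NS(=O)(=O)c4cc(NS(C)(=O)=O)ccc4N3)=C(O)[C@@H]3[C@H]4CC[C@H](C4)[C@@H]32)cc1F` gives > 1 h, a limit.

In an in vitro ADME assay on microsomes from liver (Homo sapiens) for metabolic stability, tested at 1 uM (a lower number here means that the compound disappears faster, a higher number that the compound lasts longer), compound 2 gives > 1 h, which is a limit and not a number. The record so far is the limit of > 1 h in this assay, at which 2 of the 2 values shown sit. Compound 3 `CS(=O)(=O)Nc1ccc2c(c1)S(=O)(=O)N=C(C1=C(O)[C@@H]3[C@H]4CC[C@H](C4)[C@@H]3N(Cc3ccc(F)c(F)c3F)C1=O)N2` changes one group of compound 2: 2,3,4-trifluorophenyl in place of 3-fluoro-4-methylphenyl on a saturated chain carbon bound to an amide-type nitrogen in a ring. Among the compounds with values here, the one measured step that bears on this, a step that the two limits leave unreadable from compound 1 to compound 2, touched the same place and gives no usable size. No shift in either direction is therefore expected beyond the usual scatter, and the expected step is a step that the limit leaves unreadable from compound 2 to compound 3. For compound 3 the estimate is 1.5 h, with an expected range from 0.7 h to 4 h.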

Compound 3, half-life: > 1 h
Compound 3: only a limit was reported; the forecaster's own chance of this, stated with the estimate: 75%; the middle value lies beyond the limit too.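

No step among compound 1, compound 2 and compound 3 can be read in this assay, since each result is a limit and not a number: the limit of > 1 h in this assay, at which 3 of the 3 values shown sit.

From the compounds shown here alone, how long each compound actually lasts, and whether changing the benzyl group alters that, stays open.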